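Taking the Methyl Group off Compound 2

This account rests on a few compounds, and the source may have more. Where it says the series, first, only, none or still open, it means among the compounds named here.

In a functional assay on 786-0 cells (Homo sapiens) (on this read-out higher numbers stand for weaker inhibition of growth and lower numbers for stronger inhibition of growth), compound 1 (`COc1cccc(-c2cc(O)c3cc(C)cnc3n2)c1`) reads 37.2 nM and compound 2 (`COc1cccc(-c2cc(O)c3c(C)ccnc3n2)c1`) reads 51.3 nM on this measure. These two values lie within the usual scatter of each other, so compound 2 stands level with compound 1 on the numbers available. Compound 3 (`COc1cccc(-c2cc(O)c3cccnc3n2)c1`) has not yet been measured. It differs from compound 2 by hydrogen in place of methyl on an aromatic carbon. For the measured compounds named here, no measured pair shows this kind of change directly. Going by the values given here, compound 1 at 37.2 nM and compound 2 at 51.3 nM both carry a methyl group on the shared core, and no measured compound lacks one, so the direction is uncertain. The expected change (a 1.9-fold higher number from compound 2 to compound 3 (0.29 log units; within the scatter)) is a modest move towards weaker inhibition of growth. The value expected for compound 3 is 100 nM (estimated range 30 nM to 350 nM).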

Compound 3, concentration for 50% growth inhibition: 61.7 nM
Compound 3: middle estimate off by 1.6-fold (0.21 log units), on the high side; the range from low to high includes it.
By their numbers in this assay, from the lowest: compounds 1, 2 and 3 (each within the scatter of the next).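

In this assay, a compound with no methyl group on the shared core now gives a direct reading of this change: hydrogen in place of methyl on an aromatic carbon, opposite the ring nitrogen, gives a 1.2-fold higher number from compound 2 to compound 3 (0.08 log units; within the scatter). The same exchange for the methyl group of compound 1 gives a 1.7-fold higher number from compound 1 to compound 3 (0.22 log units; within the scatter), so both steps lie within the scatter and neither methyl group is shown to be needed for growth inhibition at this level. No separate measurement bears on the reason for this result.

As far as these compounds go, whether this position tolerates only hydrogen and methyl stays open, since an ethyl group, a chlorine atom, an amine or a longer chain there could read differently. The compounds shown also leave open whether any group at this position can move the read-out beyond the scatter.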